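A few compounds are considered here, and "the series" means these few. Any claim that something is new, unique, unknown or untested is made for them only; others in the source may bear on it.

The measured compounds:

compound 1, `Cc1ccc(-c2csc(NC(=O)COc3ccccc3)n2)cc1`, 41100 nM; compound 2, `Cc1ccc(-c2csc(NC(=O)COc3ccc(Br)cc3)n2)cc1`, 37100 nM; compound 3, `O=C(COc1ccc(Br)cc1)Nc1nc(-c2ccc(Cl)cc2)cs1`, 54900 nM.

All three were tested in a functional assay on A549 cells (Homo sapiens) for cytotoxicity, read by trypan blue exclusion, with a stated time of 48 h; on this read-out higher numbers stand for weaker inhibition and lower numbers for stronger inhibition. Compound 1 and compound 2 share one core and differ in a single place: hydrogen in place of bromo on an aromatic carbon. That change gave a 1.1-fold higher number from compound 2 to compound 1 (0.04 log units; within the scatter). Compound 3 stands on a different core, and the difference between its core and that of compound 2 is chloro in place of methyl on an aromatic carbon, a change that gave a 1.5-fold higher number from compound 2 to compound 3 (0.17 log units; within the scatter). Compound 3 and compound 1 have no single-place relation here; their two values lie within the scatter of each other.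

Compound 4, `O=C(COc1ccccc1)Nc1nc(-c2ccc(Cl)cc2)cs1`, has not yet been measured in this assay . It differs from compound 3 by hydrogen in place of bromo on an aromatic carbon, the same change that separates compound 2 from compound 1, at the same place. The step is expected to be a 1.1-fold higher number from compound 3 to compound 4 (0.04 log units; within the scatter), because the earlier occurrence gave a 1.1-fold higher number from compound 2 to compound 1 (0.04 log units; within the scatter) and nothing in the three measured compounds suggests the new core would behave differently. Compound 4 is therefore estimated at 60000 nM, with a plausible range from 30000 nM to 120000 nM.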

Compound 4, half-maximal inhibitory concentration: 42800 nM
Compound 4: the middle estimate sits 1.4-fold (0.15 log units) above what was measured; measured number inside the range.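

Hydrogen in place of bromo, which turns 4-bromophenoxy into phenoxy, gave a 1.3-fold lower number from compound 3 to compound 4 (0.11 log units; within the scatter) in this assay, and this step agrees with its earlier occurrence on the core of compound 1: the same change on two cores in this assay, a 1.1-fold higher number (0.04 log units; within the scatter) from compound 2 to compound 1 and a 1.3-fold lower number (0.11 log units; within the scatter) from compound 3 to compound 4, 1.4-fold (0.15 log units) apart, within the scatter of two such steps. Chloro in place of methyl gave a 1.0-fold higher number from compound 1 to compound 4 (0.02 log units; within the scatter), and this step likewise agrees with its earlier occurrence: the same change on two cores in this assay, a 1.5-fold higher number (0.17 log units; within the scatter) from compound 2 to compound 3 and a 1.0-fold higher number (0.02 log units; within the scatter) from compound 1 to compound 4, 1.4-fold (0.15 log units) apart, within the scatter of two such steps. This shows that neither change produced a step beyond the scatter on either core, but with steps this small it does not show that a real effect of either change carries from one core to the other, only that no difference between the cores can be seen.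

The compounds shown leave open whether an amine or a carboxylic acid in place of the bromo, or a longer chain in place of the methyl, would give a step beyond the scatter. They also leave open whether these two changes would remain as small on any other core.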